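This account rests on a few compounds, and the source may have more. Where it says the series, first, only, none or still open, it means among the compounds named here.

Measured compounds and values:
- compound 1, `Cc1cn(Cc2cc(Br)ccc2OCc2ccccc2)nc1C(=O)O`: 1350 nM
- compound 2, `Cc1cc(C(=O)O)nn1Cc1cc(Br)ccc1OCc1ccc(Cl)cc1`: 8.71 nM

Of the compounds shown here, two have been measured in a functional assay on CHO-K1 cells for antagonist activity at prostaglandin E2 receptor EP1 subtype (Homo sapiens), read by FLIPR; on this read-out higher numbers stand for weaker inhibition and lower numbers for stronger inhibition. Compound 1 gives 1350 nM, while compound 2 gives 8.71 nM, the lowest of the two numbers and therefore the stronger inhibitor of the pair. The gap between them is far beyond the scatter of repeated measurements, but since the two compounds differ in more than one place, the two values can only be compared as they stand, without tying the gap to a single change.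

Compound 3, `Cc1cc(C(=O)O)nn1Cc1cc(Br)ccc1OCc1cccc([N+](=O)[O-])c1`, has not yet been measured. It differs from compound 2 in one place: 3-nitrophenyl in place of 4-chlorophenyl on a saturated chain carbon bound to an oxygen on an aromatic ring. Among the compounds with values here, no step between measured compounds covers a change of this kind, so the expectation for compound 3 rests on the value of compound 2 alone. Compound 3 is expected to give a number in this assay close to that of compound 2, with a small step to a somewhat higher number, a 2.3-fold higher number from compound 2 to compound 3 (0.36 log units; beyond the scatter), which may not exceed the scatter. Compound 3 is estimated at 20 nM, in the range 5 nM to 100 nM.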

Compound 3, inhibition constant: 339 nM
For compound 3 the middle estimate is 17-fold (1.23 log units) below the measured one; the whole stated range lies below it.
By their numbers in this assay, from the lowest: compound 2; then compound 3; then compound 1.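

In this assay, the group on a saturated chain carbon bound to an oxygen on an aromatic ring proves highly sensitive to change: 3-nitrophenyl in place of 4-chlorophenyl gives a 39-fold higher number from compound 2 to compound 3 (1.59 log units; beyond the scatter), a large step and well beyond the scatter. Both groups contain one six-membered aromatic ring of carbon only, so keeping that ring is not enough to hold the stronger inhibition of compound 2, and what the ring carries, where it carries it, or both must matter here. Nothing measured in this set explains the step, so it stands as an observation without a known cause.

Two things change together in this swap, the group on the ring and its printed ring position, so the compounds shown cannot say how much of the step belongs to each. A 3-chlorophenyl or a 4-nitrophenyl group at the same place would pull those two changes apart, while a plain phenyl group would show how the same core behaves with nothing on that ring.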